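Removing a Methoxycarbonyl Group from a Silyl-Protected Cyclopentenone

A few compounds are considered here, and "the series" means these few. Any claim that something is new, unique, unknown or untested is made for them only; others in the source may bear on it.

The study measures an ADME assay on L132 cells (Homo sapiens) for cytotoxicity, read by MTT assay, with a stated time of 72 h; a higher number here means a weaker inhibitor, a lower number a stronger inhibitor. Of the compounds shown here, three have been measured so far. Compound 1 `COc1ccc(C2=C(c3cc(OC)c(OC)c(OC)c3)C(=O)C(OC(C)=O)C2)cc1Cl` is the only one that returns a strong result: in this assay compound 1 sits at the limit of < 1 ug/mL, which is a limit of the assay rather than a number, as the limit of < 1 ug/mL in this assay, at which 1 of the 3 values shown sits, shows. Compound 3 `CC(=O)OC1C/C(=N/O)C(c2ccccc2)=C1c1ccccc1` reaches the other end: in this assay compound 3 returns > 100 ug/mL, again a limit and not a number.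

Compound 2 `COC(=O)c1cc(C2=C(c3cc(OC)c(OC)c(OC)c3)C(=O)CC2O[SiH2]C(C)(C)C)ccc1OC` stands with compound 3 at that upper edge. In this assay compound 2 gives > 100 ug/mL, a limit of the assay, and the limit of > 100 ug/mL in this assay, at which 2 of the 3 values shown sit, records that two of the three values sit there. Where compound 2 truly lies cannot be told from these numbers.

Compound 4 `COc1ccc(C2=C(c3cc(OC)c(OC)c(OC)c3)C(=O)CC2O[SiH2]C(C)(C)C)cc1` differs from compound 2 in one place: hydrogen in place of methoxycarbonyl on an aromatic carbon. Among the compounds with values here, no measured step of this kind is available, so the size of the step is open. Compound 4 is expected to remain a weak inhibitor, with an estimate of 60 ug/mL in this assay, between 10 ug/mL and 200 ug/mL, because compound 2 itself gives > 100 ug/mL. This estimate implies a step from compound 2 to compound 4 of an at least 1.6-fold lower number from compound 2 to compound 4 (0.22 log units; that floor lies within the scatter), which may well be none beyond the scatter.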

Compound 4, half-maximal inhibitory concentration: > 100 ug/mL
Compound 4: only a limit was reported; the forecaster's own chance of this, stated with the estimate: 50%; middle value at least 1.6-fold (0.22 log units) from the limit.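

In this assay compound 4 returns only a limit of the assay, as compound 2 does, and the step between compound 2 and compound 4 cannot be read. The compounds shown leave open where either compound truly lies beyond that limit, and whether hydrogen in place of methoxycarbonyl changes the result at all.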